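From a Methylbenzyl Ether to a Thienylmethyl Ether

A few compounds are considered here, and "the series" means these few. Any claim that something is new, unique, unknown or untested is made for them only; others in the source may bear on it.

Of the compounds shown here, three have been measured in a functional assay on B16 cells (Mus musculus) for cytotoxicity, read by MTT assay, with a stated time of 72 h; a lower number here means a stronger inhibitor, a higher number a weaker inhibitor. Compound 1 `COc1c(OCCCCN2CCN(C)CC2)cc(O)c2c(=O)cc(-c3ccc(F)cc3)oc12` gives 4320 nM there. Compound 2 `CCN(CC)CCCOc1c(OCc2ccccc2)cc(O)c2c(=O)cc(-c3ccccc3)oc12` gives 4900 nM. Compound 3 `Cc1ccc(COc2cc(O)c3c(=O)cc(-c4ccccc4)oc3c2OCCCCN2CCN(C)CC2)cc1` gives 3290 nM, the lowest of the three numbers, although its gaps to compound 1 and to compound 2 both lie within the scatter of repeated measurements, so no order among the three can be read from these values. No pair of these compounds differs in a single place, so no step between measured compounds is available.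

Compound 4 `CN1CCN(CCCCOc2c(OCc3cccs3)cc(O)c3c(=O)cc(-c4ccccc4)oc23)CC1` has not yet been measured. It differs from compound 3 by thiophen-2-yl in place of 4-methylphenyl on a saturated chain carbon bound to an oxygen on an aromatic ring. For the measured compounds named here, with no measured step of the same kind to draw on, and with the three measured values standing so close together in this assay, the expected step of a 1.1-fold higher number from compound 3 to compound 4 (0.03 log units; within the scatter) is small, in either direction, and not beyond the scatter. Compound 4 is therefore expected to give about 3500 nM in this assay, within a range from 1500 nM to 8000 nM.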

Compound 4, half-maximal inhibitory concentration: 2120 nM
Compound 4: the middle estimate sits 1.7-fold (0.22 log units) above what was measured; the range from low to high includes it.
By their numbers in this assay, from the lowest: compounds 4, 3, 1 and 2 (each within the scatter of the next, the first and the last beyond it).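

For the compounds shown here, the step gives the first comparison of compounds that differ in one place: with thiophen-2-yl in place of 4-methylphenyl on a saturated chain carbon bound to an oxygen on an aromatic ring, this assay shows a 1.6-fold lower number from compound 3 to compound 4 (0.19 log units; within the scatter). This place therefore takes a five-membered aromatic ring with a sulfur atom in place of a methyl-bearing six-membered ring of carbon only, with no step beyond the scatter in this pair. Nothing on hand accounts for the size of this step.

On these data alone, it remains open whether any group at this place would give a step beyond the scatter, such as a pyridine ring, a carboxylic acid or an amine. As far as these compounds go, it is equally open whether the same exchange would read alike with a diethylamino chain in place of the methylpiperazinyl butyl chain.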